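The source may report more compounds than this note shows. Statements on the series, on what has been measured and on what is new or still open speak of the compounds shown alone.

Three compounds of the series carry a shared core: compound 1 `CCC(C1CC1)n1nc(C)nc(Nc2c(Cl)cc(OC(F)F)cc2Cl)c1=O`, compound 2 `CCC(C1CC1)n1nc(C)nc(Nc2ccc(OC)nc2C(F)(F)F)c1=O` and compound 3 `COCC(C1CC1)n1nc(C)nc(Nc2ccc(OC)nc2C(F)(F)F)c1=O` have been measured. In an assay on isolated protein for displacement of a labelled ligand from corticotropin-releasing factor receptor 1 (Rattus norvegicus) (on this read-out higher numbers stand for weaker inhibition and lower numbers for stronger inhibition), compound 1 gives 2.1 nM, compound 2 gives 3.7 nM and compound 3 gives 3.7 nM. Compound 2 stands level with compound 3 at the digits shown, and compound 1 lies within the scatter of both, so no ordering among the three can be read from these numbers. Among the measured compounds shown here, the only single-point step so far, no change at the digits printed from compound 2 to compound 3 (within the scatter), concerns the saturated chain and leaves the aromatic ring untouched. Compound 4 `CCC(C1CC1)n1nc(C)nc(Nc2cc(C)c(OC)nc2C(F)(F)F)c1=O` differs from compound 2 by methyl in place of hydrogen on an aromatic carbon, a methyl in place of hydrogen on an aromatic carbon. For the measured compounds named here, no measured step alters the aromatic ring of compound 2, so there is no direct precedent; the step from compound 2 to compound 3 shows only that a small change elsewhere left this assay unmoved. A step within the scatter, in either direction, is therefore expected. Compound 4 is expected at 4 nM in this assay, with a range of 1.3 nM to 12 nM. The expected step is a 1.1-fold higher number from compound 2 to compound 4 (0.03 log units; within the scatter).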

Compound 4, half-maximal inhibitory concentration: 2.7 nM
The estimate for compound 4 lay 1.5-fold (0.17 log units) above the measured number; the range from low to high includes it.
By their numbers in this assay, from the lowest: compounds 1, 4, 2 and 3 (each within the scatter of the next).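

The aromatic ring of compound 2 now has a measured single-point change: in this assay, methyl in place of hydrogen on the aromatic carbon ortho to a methoxy group and para to a trifluoromethyl group gives a 1.4-fold lower number from compound 2 to compound 4 (0.14 log units; within the scatter), a step within the scatter. Among the compounds shown here, this position therefore takes one added carbon without a shift beyond the scatter, which the earlier compounds, with no step on this ring, could not show. No supporting data bear on the origin of this result.

From the compounds shown here alone, only hydrogen and methyl are compared at this position, so whether an ethyl group, a chlorine atom or an amine would leave the number similarly placed remains open. Also open, going by these compounds, is whether the same methyl would give a similar step on compound 3, with its methoxy-bearing chain.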